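Adding a Second Trifluoromethyl Group to a Urea

The source may hold more compounds than are shown below. What is called first, only, known or untested is meant among the compounds shown, and "the series" means these compounds.

Compound 1 `COc1cc(-c2nn(-c3cccc(NC(=O)c4cccc(C(F)(F)F)c4)c3)cc2-c2ccncc2)ccc1Cl` — 1670 nM
Compound 2 `O=C(Nc1cccc(-n2cc(-c3ccncc3)c(-c3ccc(Cl)c(O)c3)n2)c1)Nc1cc(C(F)(F)F)cc(C(F)(F)F)c1` — 428 nM
Compound 3 `COc1cc(-c2nn(-c3cccc(NC(=O)Nc4cccc(C(F)(F)F)c4)c3)cc2-c2ccncc2)ccc1Cl` — 900 nM

These three compounds were tested in a functional assay on HCT-116 cells (Homo sapiens) for inhibition, read by sulforhodamine B assay, with a stated time of 48 h; on this read-out higher numbers stand for weaker inhibition of growth and lower numbers for stronger inhibition of growth. Compound 3 stands second highest of the three numbers. Its nearest neighbour is compound 1, which gives 1670 nM; the step of a 1.9-fold lower number from compound 1 to compound 3 (0.27 log units; within the scatter) lies within the scatter. Further away is compound 2, which gives 428 nM, a lower number beyond the scatter.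

Compound 4 `COc1cc(-c2nn(-c3cccc(NC(=O)Nc4cc(C(F)(F)F)cc(C(F)(F)F)c4)c3)cc2-c2ccncc2)ccc1Cl` differs from compound 3 in one place: trifluoromethyl in place of hydrogen on an aromatic carbon.

Among the compounds with values here, no measured step covers this change by itself. Within the data shown here, the only measured step, a 1.9-fold lower number from compound 1 to compound 3 (0.27 log units; within the scatter), concerns a different change and is within the scatter. Compound 2 also carries two trifluoromethyl groups, but it differs from compound 3 in a second place as well, so its lower number gives only a hint that a compound with two such groups can give a lower number. A modest downward step is therefore expected, a 1.6-fold lower number from compound 3 to compound 4 (0.21 log units; within the scatter). Compound 4 is expected to give about 550 nM, within a range from 250 nM to 1200 nM.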

Compound 4, concentration for 50% growth inhibition: 643 nM
Beside the measured number, compound 4's estimate is 1.2-fold (0.07 log units) below it; measured number inside the range.
By their numbers in this assay, from the lowest: compounds 2, 4, 3 and 1 (each within the scatter of the next, the first and the last beyond it).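

In this assay, trifluoromethyl in place of hydrogen on this aromatic carbon, meta to a trifluoromethyl group, gives a 1.4-fold lower number from compound 3 to compound 4 (0.15 log units; within the scatter), so this change alone cannot be told apart from repeat-to-repeat variation. Methyl in place of hydrogen on the oxygen on an aromatic ring, now seen with both trifluoromethyl groups present, gives a 1.5-fold higher number from compound 2 to compound 4 (0.18 log units; within the scatter) and also stays within the scatter. Compound 2 and compound 3 differ in two places, and each of those two changes, read alone, is too small to count as a real difference.

Nothing measured here offers a reason for these small steps. On these data alone, whether a chlorine atom, a nitrile or an amine at this position would give a step beyond the scatter remains open.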